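This account rests on a few compounds, and the source may have more. Where it says the series, first, only, none or still open, it means among the compounds named here.

Measured so far in a functional assay on HSC-3 cells (Homo sapiens) for cytotoxicity; a higher number here means that more compound is tolerated, a lower number that less compound is tolerated:
compound 1 `COc1cc(/C=C2\Cc3ccccc3/C(=C\c3ccc([N+](=O)[O-])cc3)C2=O)ccc1O` gives 3800 nM
compound 2 `COc1cc(/C=C2\Cc3ccccc3/C(=C\c3ccc([N+](=O)[O-])cc3)C2=O)cc(OC)c1OC` gives 2900 nM
compound 3 `COc1ccc(/C=C2\Cc3ccccc3/C(=C\c3ccc([N+](=O)[O-])cc3)C2=O)cc1` gives 32000 nM

Compound 3 stands highest of the three, beyond the scatter from both others. The step to compound 4 `COc1ccc(/C=C2\Cc3ccccc3/C(=C\c3ccc([N+](=O)[O-])cc3)C2=O)cc1OC` is methoxy in place of hydrogen on an aromatic carbon. For the measured compounds named here, the one measured step that bears on this position is an 8.4-fold higher number from compound 1 to compound 3 (0.93 log units; beyond the scatter), where taking away the group at that site raised the number. Compound 2, which carries methoxy groups flanking the 4-methoxy, gives 2900 nM; compound 3 gives 32000 nM. Both comparisons point the same way: a substituent at this position goes with a lower number. A lower number is therefore expected for compound 4, with a 4.6-fold lower number from compound 3 to compound 4 (0.66 log units; beyond the scatter) as the estimated step. Compound 4 is estimated at 7000 nM, within 2500 nM to 20000 nM.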

Compound 4, half-maximal cytotoxic concentration: 4200 nM
Estimate against measurement, compound 4: 1.7-fold (0.22 log units) above; the measured number falls inside the stated range.
By their numbers in this assay, from the lowest: compounds 2, 1 and 4 (each within the scatter of the next); then compound 3.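

In this assay, methoxy in place of hydrogen on the aromatic carbon ortho to a methoxy group gives a 7.6-fold lower number from compound 3 to compound 4 (0.88 log units; beyond the scatter), so a hydroxy group at that site is not required for the lower number. Methyl in place of hydrogen on that oxygen gives a 1.1-fold higher number from compound 1 to compound 4 (0.04 log units; within the scatter), and hydrogen in place of methoxy on an aromatic carbon gives a 1.4-fold higher number from compound 2 to compound 4 (0.16 log units; within the scatter), so compounds 1, 2 and 4 form one level, with only compound 3 apart from it. No measurement shown speaks to what lies behind these steps.

The compounds shown leave open whether this site needs an oxygen at all, as an amine or a methyl group there would show. Going by these compounds, whether a longer chain on that oxygen, such as ethoxy, stays at the same level also remains open.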